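A few compounds are considered here, and "the series" means these few. Any claim that something is new, unique, unknown or untested is made for them only; others in the source may bear on it.

Measured so far in a functional assay on A-431 cells (Homo sapiens) for cytotoxicity; a lower number here means that less compound is needed, a higher number that more compound is needed for the effect:
Compound 1 `COC1=C(C)C(=O)/C(=C(O)/C=C/c2ccc(OC)cc2)C(=O)C1(C)C`: 9.2 ug/mL
Compound 2 `COC1=C(C)C(=O)/C(=C(O)/C=C/c2ccc(C)cc2)C(=O)C1(C)C`: 5.1 ug/mL

Only these two numbers exist, and they cannot be ranked, since the values of compound 1 and compound 2 lie within the scatter of each other. The next compound to be tested, compound 3 `C=Cc1ccccc1/C=C/C(O)=C1/C(=O)C(C)=C(OC)C(C)(C)C1=O`, keeps the shared core and changes one group: 2-vinylphenyl in place of 4-methylphenyl on a double-bonded chain carbon bound to a double-bonded chain carbon. For the measured compounds named here, only one measured step bears on this change, and only indirectly. It replaced methoxy with methyl on an aromatic carbon, giving a 1.8-fold lower number from compound 1 to compound 2 (0.26 log units; within the scatter). Going by the values given here, no measured compound carries 2-vinylphenyl, so the data offer no direct guide to this group. With that single small step from compound 2 as the guide, no change beyond the scatter is expected in this assay. The estimated 1.2-fold higher number from compound 2 to compound 3 (0.07 log units; within the scatter) is therefore small. For compound 3 the expected value is 6 ug/mL, with an estimated range of 2.5 ug/mL to 14 ug/mL.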

Compound 3, concentration for half-maximal effect: 2.6 ug/mL
The estimate for compound 3 lay 2.3-fold (0.36 log units) above the measured number, within the range that was stated.
By their numbers in this assay, from the lowest: compounds 3, 2 and 1 (each within the scatter of the next, the first and the last beyond it).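

In this assay, 2-vinylphenyl in place of 4-methylphenyl on a double-bonded chain carbon bound to a double-bonded chain carbon gives a 2.0-fold lower number from compound 2 to compound 3 (0.29 log units; within the scatter), so this step alone cannot be told apart from repeat variation. Set against 4-methoxyphenyl at the same place, the same group gives a 3.5-fold lower number from compound 1 to compound 3 (0.55 log units; beyond the scatter), the first step in this series to pass beyond the scatter, and it shows that the aromatic ring here can carry 2-vinylphenyl without any loss in this read-out. No measurement shown here offers an explanation for this difference.

The compounds shown leave open whether the vinyl group or its place on the ring matters more, since the step from 4-methylphenyl alters both at once. From the compounds shown here alone, how a ring bearing an amine or a carboxylic acid would behave at this place also remains open.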